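Swapping dimethylamino for a trifluoropropylamino group

This account rests on a few compounds, and the source may have more. Where it says the series, first, only, none or still open, it means among the compounds named here.

In an ADME assay on microsomes from liver (Macaca fascicularis) for metabolic stability, read by LC-MS, with a stated time of 65 min, tested at 1 uM (a higher number here means that more of the compound is left, a lower number that less of the compound is left), compound 1 `Fc1cc2nc(-c3cncnc3)n(C3CC3)c2cc1F` gives 98%, while compound 2 `CN(C)c1ncncc1-c1nc2cc(F)c(F)cc2n1C1CC1` gives 6%, the lower of the two numbers. Compound 3 `Fc1cc2nc(-c3cncnc3NCCC(F)(F)F)n(C3CC3)c2cc1F` keeps the shared core but carries (3,3,3-trifluoropropyl)amino in place of dimethylamino on an aromatic carbon. Within the data shown here, only one measured step bears on this change: a number 92 percentage points lower from compound 1 to compound 2 (beyond the scatter), a large drop when dimethylamino took the place of hydrogen on an aromatic carbon. Among the measured compounds shown here, no measured compound carries the new group, so this step gives only a loose guide. With compound 2 at 6%, there is little room to fall, and a rise beyond the scatter in this assay is expected, though smaller than that drop. The estimated step is a number 29 percentage points higher from compound 2 to compound 3 (beyond the scatter). For compound 3 the expected value is 35%, with an estimated range of 10% to 75%.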

Compound 3, percent of the compound remaining: 55%
Estimate against measurement, compound 3: 20 percentage points below, within the range that was stated.
By their numbers in this assay, from the lowest: compound 2; then compound 3; then compound 1.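

In this assay there is a number 49 percentage points higher from compound 2 to compound 3 (beyond the scatter) when (3,3,3-trifluoropropyl)amino replaces dimethylamino, so at this position the result depends on which amino group is attached, not only on there being one. Hydrogen at the same place still stands apart, with a number 43 percentage points lower from compound 1 to compound 3 (beyond the scatter), so the new group regains only part of what was lost with dimethylamino. No measurement here gives a reason for the difference between the two amino groups.

The compounds shown leave open which feature of the new group matters: its fluorine atoms, its chain length or the hydrogen on its nitrogen. A plain propylamino group, a methylamino group or a cyclic amine such as morpholine at this place would help to separate these features.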